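Morpholine in place of methoxypropylamino on a sulfonyl group

The source may report more compounds than this note shows. Statements on the series, on what has been measured and on what is new or still open speak of the compounds shown alone.

Of the compounds shown here, two have been measured in a physicochemical assay for solubility, read by HPLC; a lower number here means a less soluble compound, a higher number a more soluble compound. Compound 1 `O=[N+]([O-])c1nccn1CCS(=O)(=O)NCCO` gives 75300000 nM. Compound 2 `COCCCNS(=O)(=O)CCn1c([N+](=O)[O-])cnc1C` gives 17000000 nM, the lower of the two numbers, and its nearest neighbour is compound 1, whose number is higher by a margin beyond the usual scatter. Going by the values given here, the two compounds differ in more than one place, so nothing can be said about the size of a single change between them; their two values show only that compound 2 is the less soluble of the pair.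

Compound 3 `Cc1ncc([N+](=O)[O-])n1CCS(=O)(=O)N1CCOCC1` has not been measured. It differs from compound 2 in one place: morpholin-4-yl in place of (3-methoxypropyl)amino on a sulfonyl sulfur. Among the compounds with values here, no step between measured compounds separates the effect of this exchange, so the expectation for compound 3 rests on compound 2 alone. The change is expected to move the number in this assay little, perhaps slightly downward, a step that would remain within the usual scatter, and the step from compound 2 to compound 3 is estimated at a 1.4-fold lower number from compound 2 to compound 3 (0.15 log units; within the scatter). Compound 3 is therefore expected to give about 12000000 nM, within a range from 4000000 nM to 40000000 nM.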

Compound 3, solubility: 2770000 nM
Compound 3: the middle estimate sits 4.3-fold (0.64 log units) above what was measured, and the stated range ends above it.
By their numbers in this assay, from the lowest: compound 3; then compound 2; then compound 1.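

In this assay, the sulfonyl sulfur turns out to be a place where the exchange of one group for another can be read on its own: morpholin-4-yl in place of (3-methoxypropyl)amino gives a 6.1-fold lower number from compound 2 to compound 3 (0.79 log units; beyond the scatter). The two groups have the same count of heavy atoms, carbon, nitrogen and oxygen, so the step separates groups that differ in form, with the entering group holding a six-membered non-aromatic ring and 0 hydrogen-bond donors where the leaving chain has no ring and 1 hydrogen-bond donor. These two differences arrive together in this single exchange, and no measurement shown here accounts for the step.

The compounds shown leave open whether the ring or the lost donor carries the step, which a piperidine or an open-chain group with a methyl on the sulfonamide nitrogen could begin to separate. They also leave open whether the same exchange would give a step of similar size on the core of compound 1.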